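Urea-linked quinolines in a liver-cell toxicity assay

A few compounds are considered here, and "the series" means these few. Any claim that something is new, unique, unknown or untested is made for them only; others in the source may bear on it.

Measured so far:
compound 1 `Cc1cc(NC(=O)Nc2ccc(N(C)C)cc2)c2ccccc2n1` — > 25000 nM
compound 2 `Cc1cc(NC(=O)Nc2ccc(C(F)(F)F)cc2)c2ccccc2n1` — 23000 nM
compound 3 `Cc1cc(NC(=O)Nc2cccc(C(F)(F)F)c2)c2ccccc2n1` — 21000 nM

In an ADME assay on HepG2 cells (Homo sapiens) for cytotoxicity, with a stated time of 72 h (a higher number here means that more compound is needed for the effect, a lower number that less compound is needed), compound 1 reaches only a limit of the assay, > 25000 nM, and no number. Compound 2 and compound 3 each give a number in this assay, and their values sit within the scatter of each other. Among the measured compounds shown here, the one measured step is an at least 1.0-fold higher number from compound 2 to compound 1 (0.03 log units; that floor lies within the scatter), the change being (dimethylamino in place of trifluoromethyl on an aromatic carbon). How the core of compound 2 and the core of compound 3 differ is not broken down here.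

Compound 4 `Cc1cc(NC(=O)Nc2cccc(N(C)C)c2)c2ccccc2n1` is not yet measured. It differs from compound 3 by dimethylamino in place of trifluoromethyl on an aromatic carbon. The place is not identical to that in compound 1: there the group sits para to a large group, here meta to a large group, so this is the same kind of change, not the same change.

The step from compound 3 to compound 4 is expected to be a 1.2-fold higher number from compound 3 to compound 4 (0.09 log units; within the scatter), resting on an at least 1.0-fold higher number from compound 2 to compound 1 (0.03 log units; that floor lies within the scatter) and on (the limit of > 25000 nM in this assay, at which 1 of the 3 values shown sits). For compound 4 the estimate in this assay is 26000 nM, between 14000 nM and 50000 nM.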

Compound 4, half-maximal effective concentration: > 25000 nM
Compound 4 was reported as a limit; the forecaster's own chance of this, stated with the estimate: 50%; the middle value does not contradict the limit.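

In this assay compound 4 gives > 25000 nM, which is a limit of the assay and not a number. Dimethylamino in place of trifluoromethyl gives an at least 1.1-fold higher number from compound 3 to compound 4 (0.07 log units; that floor lies within the scatter), and set beside the earlier step the two cores compare as follows: the same change on two cores in this assay, an at least 1.0-fold higher number (0.03 log units; that floor lies within the scatter) from compound 2 to compound 1 and an at least 1.1-fold higher number (0.07 log units; that floor lies within the scatter) from compound 3 to compound 4; the limit leaves it open whether they differ This shows only that the change ends at the assay's limit on both cores; it does not show that a step of any particular size carries from one core to the other, or that the change moves the number beyond the scatter at all, as both steps are floors: the limit of > 25000 nM in this assay, at which 2 of the 4 values shown sit.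

The compounds shown leave open what other groups on the same aromatic carbon would give, for instance a carboxylic acid, a primary amine or a longer alkyl chain. They also leave open whether any such group would yield a number clearly apart from those of compound 2 and compound 3 in this assay.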